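Aryl swap on the hydrazone of compound 1: cytotoxicity outlook

This account rests on a few compounds, and the source may have more. Where it says the series, first, only, none or still open, it means among the compounds named here.

Compound 1 `COc1ccccc1-c1nnc(-c2ccc(C(=O)N/N=C/c3ccc(F)cc3)cc2)o1` carries a 4-fluorophenyl on a carbon with a double bond to nitrogen. Among the compounds with values here, in an ADME assay on THP-1 cells (Homo sapiens) for cytotoxicity (a higher number here means a weaker inhibitor, a lower number a stronger inhibitor), compound 1 gives 427000 nM, the highest of the two numbers measured so far. Within the data shown here, its single measured neighbour is compound 2 `COc1ccccc1-c1nnc(-c2ccc(C(=O)N/N=C/c3ccc(Cl)cc3Cl)cc2)o1`, which in this assay gives 78800 nM; the step of a 5.4-fold lower number from compound 1 to compound 2 (0.73 log units; beyond the scatter) is the only one recorded.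

Compound 3 `COc1ccc(/C=N/NC(=O)c2ccc(-c3nnc(-c4ccccc4OC)o3)cc2)c(O)c1` is not yet measured. Its change from compound 1 is 2-hydroxy-4-methoxyphenyl in place of 4-fluorophenyl on a carbon with a double bond to nitrogen. Among the measured compounds shown here, no measured step covers a change of this kind; the only guidance is the aryl swap from compound 1 to compound 2, which moved the number by a modest amount. For the measured compounds named here, the step to compound 3 is therefore expected to be small and its direction uncertain, possibly within the scatter, with a slight lean toward a lower number on the basis of the one aryl swap seen. For compound 3 the estimated step is a 1.7-fold lower number from compound 1 to compound 3 (0.23 log units; within the scatter). In this assay compound 3 is expected to give about 250000 nM, within a range from 70000 nM to 900000 nM.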

Compound 3, half-maximal inhibitory concentration: 308000 nM
Compound 3: middle estimate off by 1.2-fold (0.09 log units), on the low side; the range from low to high includes it.
By their numbers in this assay, from the lowest: compound 2; then compounds 3 and 1 (each within the scatter of the next).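

In this assay, 2-hydroxy-4-methoxyphenyl in place of 4-fluorophenyl on the carbon with a double bond to nitrogen gives a 1.4-fold lower number from compound 1 to compound 3 (0.14 log units; within the scatter) and so brings in a hydrogen-bond donor and hydrogen-bond acceptors without a change beyond the scatter. The same group in place of 2,4-dichlorophenyl gives a 3.9-fold higher number from compound 2 to compound 3 (0.59 log units; beyond the scatter) and so shows that, among the three aryl groups seen at this position, only the 2,4-dichlorophenyl of compound 2 stands apart, while a new aryl group here does not by itself bring a lower number. Nothing measured on these compounds bears on the reason for this difference.

Open, from the compounds shown here alone, is whether both chlorines are needed for the lower number of compound 2 or whether a 4-chlorophenyl group would read the same. Also open, going by these compounds, is how the hydroxyl and methoxy groups of compound 3 would each read alone at this position, and how an amine or a carboxylic acid on the same aryl ring would read.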